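Fixing Both Ring Stereocentres of a Stable Amide

The source may hold more compounds than are shown below. What is called first, only, known or untested is meant among the compounds shown, and "the series" means these compounds.

Compound 1 `Cc1cc(CN2C(=O)C(C3=NS(=O)(=O)c4cc(NS(C)(=O)=O)ccc4N3)=C(O)[C@H]3CCC[C@H]32)ccc1F`: > 1 h
Compound 2 `CS(=O)(=O)Nc1ccc2c(c1)S(=O)(=O)N=C(C1=C(O)C3CCCCC3N(Cc3ccc(F)cc3)C1=O)N2`: > 1 h
Compound 3 `CC(C)(C)CCN1C(=O)C(C2=NS(=O)(=O)c3cc(NS(C)(=O)=O)ccc3N2)=C(O)C2CCCCC21`: 0.267 h

In an in vitro ADME assay on microsomes from liver (Homo sapiens) for metabolic stability (on this read-out lower numbers stand for a shorter-lived compound and higher numbers for a longer-lived compound), compound 1 reaches > 1 h, which is a limit of the assay rather than a number. Compound 2 likewise reaches > 1 h, again a limit. Compound 3 gives 0.267 h. Compound 2 therefore stands at the limit of > 1 h in this assay, at which 2 of the 3 values shown sit, alongside compound 1, with compound 3 the only one lower. Compound 4 `CS(=O)(=O)Nc1ccc2c(c1)S(=O)(=O)N=C(C1=C(O)[C@@H]3CCCC[C@@H]3N(Cc3ccc(F)cc3)C1=O)N2` differs from compound 2 as follows: the two compounds have the same atoms and bonds; at least one stereo element is drawn with a configuration in one of them and without one in the other: 2 of 2 stereo elements differ; a stereocentre at a saturated ring carbon is drawn without a configuration in compound 2 and R in compound 4; a stereocentre at a saturated ring carbon is drawn without a configuration in compound 2 and S in compound 4. No measured step concerns a change of this kind; the single step shown, an at least 3.7-fold lower number from compound 2 to compound 3 (0.57 log units; beyond the scatter), exchanges one group for another and does not bear on it. With identical atoms and bonds, compound 4 is expected to sit close to compound 2, a step that the limit leaves unreadable from compound 2 to compound 4 that is expected to remain within the scatter. Compound 4 is thus estimated at 1.6 h, in the range 0.7 h to 4 h.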

Compound 4, half-life: > 1 h
Compound 4 was reported as a limit (the forecaster's own chance of this, stated with the estimate: 75%); the middle value lies beyond the limit too.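

In this assay, among these compounds, compound 2 and compound 4 each give only a limit of the assay, so no step between them can be read. From the compounds shown here alone, whether the configuration drawn in compound 4 changes the half-life remains open.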